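The compounds below may be only part of what the source reports. "The series", "measured", "known", "first", "only" and "open" are said of these compounds alone.

Of the compounds shown here, three have so far been tested in a functional assay on KYSE-410 cells (Homo sapiens) for antiproliferative activity, read by MTT assay, with a stated time of 72 h; on this read-out higher numbers stand for weaker inhibition and lower numbers for stronger inhibition. Compound 1 has the structure `O=C(c1ccnc2cc(Br)ccc12)N1CCCCC1`; in this assay compound 1 gives > 20000 nM, which is a limit of the assay rather than a number. Compound 2, with the structure `COc1ccc2c(C(=O)Nc3cc(F)cc(F)c3)cc(=O)[nH]c2c1`, gives > 20000 nM in this assay, again only a limit. Compound 3, with the structure `O=C(Nc1cccc(F)c1)c1cc(=O)[nH]c2cc(-c3ccccc3)ccc12`, gives > 20000 nM in this assay, also a limit and not a number. Within the data shown here, compound 3 therefore stands nowhere apart from the others: every result shown sits at the limit of > 20000 nM in this assay, at which 3 of the 3 values shown sit, and no measured step separates any two of them. Compound 4, with the structure `O=C(Nc1cccc(F)c1)c1cc(=O)[nH]c2cc(C3=CCOCC3)ccc12`, differs from compound 3 by a group of 6 heavy atoms (5 carbon, 1 oxygen; one six-membered non-aromatic ring with 1 hetero atom) in place of a group of 6 heavy atoms (6 carbon; one six-membered aromatic ring of carbon only), on an aromatic carbon. With all measured values resting at the limit, the change is expected to bring a step that the limit leaves unreadable from compound 3 to compound 4, most likely none beyond the scatter. Compound 4 is thus expected to give about 25000 nM, between 5000 nM and 100000 nM.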

Compound 4, half-maximal inhibitory concentration: 12100 nM
Compound 4: middle estimate off by 2.1-fold (0.32 log units), on the high side, and the stated range covers the measured number.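

In this assay, among these compounds, replacing phenyl with the six-membered non-aromatic ring containing one oxygen on this aromatic carbon brings an at least 1.6-fold lower number from compound 3 to compound 4 (0.21 log units; that floor lies within the scatter), and compound 4 gives the first true number. This shows that the position can carry a non-aromatic ring with a hydrogen-bond acceptor and still give a readable value. The full size of the step cannot be read, because compound 3 rests at a limit: the limit of > 20000 nM in this assay, at which 3 of the 4 values shown sit.

As far as these compounds go, whether an amine such as piperazine or a carboxylic acid on the same carbon would lower the number further remains open.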